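A few compounds are considered here, and "the series" means these few. Any claim that something is new, unique, unknown or untested is made for them only; others in the source may bear on it.

Among the compounds with values here, in a functional assay on HepG2 cells (Homo sapiens) for antiproliferative activity, read by CCK-8 assay, with a stated time of 48 h (on this read-out higher numbers stand for weaker inhibition and lower numbers for stronger inhibition), compound 3 (`COc1ccc(/C=C\c2cc(OC)c(OC)c(OC)c2)cc1OCc1ccc(CNCCN(C)C)cc1`) gives 4400 nM, the only actual number so far. Compound 1 (`COc1ccc(/C=C\c2cc(OC)c(OC)c(OC)c2)cc1OCc1ccc(CN2C[C@H](O)C[C@@H]2C(=O)O)cc1`) sits at the limit > 10000 nM. Compound 2 (`COc1ccc(/C=C\c2cc(OC)c(OC)c(OC)c2)cc1OCc1ccc(CN2CCCC[C@@H]2C(=O)O)cc1`) sits at the limit > 10000 nM. Compound 4 (`COc1ccc(/C=C\c2cc(OC)c(OC)c(OC)c2)cc1OCc1ccc(CN2CCCCC2C(=O)NCCN)cc1`) differs from compound 3 as follows: 2-((2-aminoethyl)carbamoyl)piperidin-1-yl in place of (2-(dimethylamino)ethyl)amino on a saturated chain carbon bound to an aromatic carbon. Within the data shown here, two measured steps bear on this change: an at least 2.2-fold lower number from compound 2 to compound 3 (0.35 log units; beyond the scatter) and an at least 2.2-fold lower number from compound 1 to compound 3 (0.35 log units; beyond the scatter). Both give only a minimum size. Compound 4 keeps the piperidine ring of compound 2 but has an amide in place of its carboxy group, and it carries an aminoethyl chain resembling that of compound 3 at 4400 nM. The expected change in this assay is therefore none beyond the scatter, as a 1.3-fold higher number from compound 3 to compound 4 (0.10 log units; within the scatter). For compound 4 the estimated value is 5500 nM, with an expected range of 1800 nM to 10000 nM.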

Compound 4, half-maximal inhibitory concentration: 4800 nM
Estimate against measurement, compound 4: 1.1-fold (0.06 log units) above; the measured number falls inside the stated range.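

In this assay, a piperidine-bearing group on the saturated chain carbon bound to an aromatic carbon proves compatible with measurable activity: 2-((2-aminoethyl)carbamoyl)piperidin-1-yl for (2-(dimethylamino)ethyl)amino gives a 1.1-fold higher number from compound 3 to compound 4 (0.04 log units; within the scatter). Against the two carboxy compounds, the same group gives an at least 2.0-fold lower number from compound 2 to compound 4 (0.31 log units; beyond the scatter) and an at least 2.0-fold lower number from compound 1 to compound 4 (0.31 log units; beyond the scatter). Compound 2, with the same piperidine ring, stays at a limit of the assay, > 10000 nM.

Going by these compounds, it remains open whether the amide or the aminoethyl chain accounts for these steps. An unsubstituted primary carboxamide or a longer aminopropyl chain on the amide would help separate the two.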